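The source may hold more compounds than are shown below. What is called first, only, known or untested is meant among the compounds shown, and "the series" means these compounds.

Measured compounds so far:
compound 1, `O=C(N/N=C/c1cccc(F)c1)c1cccnc1Nc1cccc(C(F)(F)F)c1`, 29.8%
compound 2, `COc1cccc(/C=N/NC(=O)c2cccnc2Nc2cccc(C(F)(F)F)c2)c1`, 14.9%

Both were read in a functional assay on the whole organism (strain Wistar) for inhibition, with Rattus norvegicus as the target, read by paw edema, with a stated time of 4 h, at a dose of 10 mg/kg by the intraperitoneal route; a higher number here means more inhibition at the dose given (going by the name of the read-out), a lower number less inhibition. Among the measured compounds shown here, compound 2 gives the lowest of the two numbers; its nearest neighbour is compound 1, and the single measured step of a number 14.9 percentage points lower from compound 1 to compound 2 (beyond the scatter) lies beyond the scatter. Compound 3, `CNc1ncccc1C(=O)N/N=C/c1cccc(OC)c1`, has not been measured. The change from compound 2 is methyl in place of 3-(trifluoromethyl)phenyl on a nitrogen on an aromatic ring. For the measured compounds named here, no measured step bears on this change: the only step seen concerns the fluoro and methoxy groups on the aromatic carbon, not the substituent on the aromatic nitrogen, so the expectation rests on compound 2 alone. With the larger group gone, the number is expected to stay near that of compound 2 or fall a little, the step of a number 4.9 percentage points lower from compound 2 to compound 3 (within the scatter) being the estimated change. Compound 3 is therefore estimated at 10%, within 0% to 28%.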

Compound 3, a percentage reported as inhibition, in the whole organism at one dose (the size of the read-out at that dose, not a potency): 42.3%
Compound 3: middle estimate off by 32.3 percentage points, on the low side; the measured number lies above the stated range.
By their numbers in this assay, from the lowest: compound 2; then compound 1; then compound 3.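

In this assay the substituent on the nitrogen turns out to carry weight: with methyl in place of 3-(trifluoromethyl)phenyl, the result is a number 27.4 percentage points higher from compound 2 to compound 3 (beyond the scatter). Among the compounds shown here, the earlier step concerned only fluoro and methoxy on an aromatic carbon, so this is the first reading at this position, and it shows that in the methoxy compounds the 3-(trifluoromethyl)phenyl group is not required for inhibition at this dose. Nothing available accounts for the rise.

As far as these compounds go, it remains open whether the gain belongs to methyl itself or simply follows the loss of the aromatic ring; a free amine or a longer chain such as n-propyl on that nitrogen would separate the two. Also open, from the compounds shown here alone, is whether methyl on the nitrogen gives a similar result with fluoro in place of methoxy.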